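The source may hold more compounds than are shown below. What is called first, only, known or untested is meant among the compounds shown, and "the series" means these compounds.

In a functional assay (aorta) with Rattus norvegicus as the target (on this read-out higher numbers stand for weaker inhibition and lower numbers for stronger inhibition), three compounds sharing one core have been measured. Compound 1 `COC(=O)c1cc2ccccc2n1[C@@H]1c2cc(C#N)ccc2OC(C)(C)[C@H]1O` gives 33000 nM, and compound 3 `CCOC(=O)CN(c1nc(C)cs1)[C@H]1c2cc(C#N)ccc2OC(C)(C)[C@@H]1O` gives 84000 nM. Compound 2 `CC1(C)Oc2ccc(C#N)cc2[C@H](N(CC(=O)O)c2ccccc2)[C@H]1O` reaches only the limit of the assay, > 100000 nM, and no number. That value is the one sitting at the limit of > 100000 nM in this assay, at which 1 of the 3 values shown sits. Compound 4 `CC1(C)Oc2ccc(C#N)cc2[C@H](N(CC#N)c2ccccc2)[C@H]1O` differs from compound 2 in one place: cyano in place of carboxy on a saturated chain carbon bound to a nitrogen on an aromatic ring. Going by the values given here, no measured pair shows this change, so the size of the step rests on expectation alone. Because compound 1 gives 33000 nM and compound 3 gives 84000 nM, compound 4 is expected to return a number rather than a limit. The expected step from compound 2 to compound 4 is an at least 2.0-fold lower number from compound 2 to compound 4 (0.30 log units; that floor lies within the scatter), toward stronger inhibition. Compound 4 is estimated at 50000 nM, between 15000 nM and 150000 nM.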

Compound 4, half-maximal inhibitory concentration: 59000 nM
Estimate against measurement, compound 4: 1.2-fold (0.07 log units) below; low and high end bracket the measured number.
By their numbers in this assay, from the lowest: compounds 1, 4 and 3 (each within the scatter of the next, the first and the last beyond it). At a limit, above all of these: compound 2.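

In this assay, going by these compounds alone, the change from carboxymethyl to cyanomethyl on the saturated chain carbon bound to a nitrogen on an aromatic ring gives the first readable step at this position: an at least 1.6-fold lower number from compound 2 to compound 4 (0.22 log units; that floor lies within the scatter). Compound 2 remains a limit of the assay, > 100000 nM, and not a number. With the cyano group in place, compound 4 gives a number, 59000 nM.

As far as these compounds go, the true size of the step stays open. The compounds shown also do not tell how an amine, a primary amide or a longer chain ending in a nitrile would read at this place.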